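A few compounds are considered here, and "the series" means these few. Any claim that something is new, unique, unknown or untested is made for them only; others in the source may bear on it.

Compound 2 `Cn1c(Cc2nn(C)c(=O)c3ccccc23)nnc1SCCCCCCCC(=O)Nc1ccc(Cl)cc1Cl` is the only entry in this series with a number: in an assay on isolated protein for binding affinity to interleukin-2 (Homo sapiens), read by surface plasmon resonance (on this read-out higher numbers stand for weaker binding and lower numbers for tighter binding), compound 2 gives 8000 nM, so on the numbers shown it stands alone, with nothing to rank it against. Compound 1 `CCCOc1ccc(NC(=O)CCCCCCCSc2nnc(Cc3nn(C)c(=O)c4ccccc34)n2C)cc1`, which carries the same long chain and the same core, has no result in this assay ("not determined" (no result reported)). Compound 3 `Cn1c(Cc2nn(C)c(=O)c3ccccc23)nnc1SCCCCCCCC(=O)Nc1ccc(Br)cc1Br` has not yet been measured in this assay. The difference between compound 2 and compound 3 is 2,4-dibromophenyl in place of 2,4-dichlorophenyl on an amide-type nitrogen. No step between two measured compounds is available to guide the size of this change, and a swap of one halogen pair for another on the amide-type nitrogen gives no reason from these data to expect more than the usual scatter. The step from compound 2 to compound 3 is therefore expected to be a 1.3-fold lower number from compound 2 to compound 3 (0.12 log units; within the scatter), essentially no change. Compound 3 is estimated at 6000 nM in this assay, within a range from 2500 nM to 15000 nM.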

Compound 3, dissociation constant: 10000 nM
The estimate for compound 3 lay 1.7-fold (0.22 log units) below the measured number; measured number inside the range.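

In this assay, among these compounds, the only step that can be read at this position, on the amide-type nitrogen, is a 1.3-fold higher number from compound 2 to compound 3 (0.10 log units; within the scatter). This shows that 2,4-dibromophenyl in place of 2,4-dichlorophenyl, a swap that keeps the ring and the count of heavy atoms, does not move the read-out beyond the usual scatter, so the two halogen pairs cannot be told apart here. Nothing available bears on why these two compounds read alike.

Steps to compound 1 cannot be read, so the 2,4-dihalophenyl pair remains the only comparison at this position. Still open, going by these compounds, is whether a phenyl ring carrying an amine or a carboxylic acid on the amide-type nitrogen, or a shorter chain in the linker, would shift the number beyond the scatter.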